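The source may report more compounds than this note shows. Statements on the series, on what has been measured and on what is new or still open speak of the compounds shown alone.

Measured so far in a functional assay (aorta) with Rattus norvegicus as the target; on this read-out higher numbers stand for an effect only at larger amounts of compound and lower numbers for an effect already at smaller amounts:
Compound 1 `CNC1=NS(=O)(=O)c2cc(F)ccc2N1` gives > 300 uM, a limit of the assay.
Compound 2 `CCNC1=NS(=O)(=O)c2cc(F)ccc2N1` gives > 300 uM, likewise a limit.
Among the compounds with values here, compound 3 `CCNC1=NS(=O)(=O)c2cc(Br)ccc2N1` gives 6.2 uM, the only number among the three.

Compound 1 and compound 2 both sit at the limit of > 300 uM in this assay, at which 2 of the 3 values shown sit, so the change methyl in place of hydrogen on a saturated chain carbon bound to an amine nitrogen yields a step that the two limits leave unreadable from compound 1 to compound 2. The step of an at least 48-fold lower number from compound 2 to compound 3 (1.68 log units; beyond the scatter) is large. The difference between the core of compound 1 and the core of compound 3 is not broken down here.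

Compound 4 `CCCNC1=NS(=O)(=O)c2cc(Br)ccc2N1` carries the change (methyl in place of hydrogen on a saturated chain carbon, two bonds along the chain from an amine nitrogen). This is the same kind of change as that from compound 1 to compound 2, but the place differs: bound to an amine nitrogen there, two bonds along the chain from an amine nitrogen here. The earlier step gives no readable size, so the expectation for compound 4 rests on compound 3 alone at 6.2 uM. The expected step is a 1.2-fold lower number from compound 3 to compound 4 (0.09 log units; within the scatter), within scatter. Compound 4 is estimated at 5 uM, between 1.5 uM and 20 uM.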

Compound 4, concentration for half-maximal effect: 5.9 uM
Compound 4: middle estimate off by 1.2-fold (0.07 log units), on the low side; the range from low to high includes it.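

In this assay, ethylamino to propylamino on the bromo core gives a 1.1-fold lower number from compound 3 to compound 4 (0.02 log units; within the scatter), so the two values cannot be told apart. Within the data shown here, the step on the fluoro core puts the methyl at a different place, on a saturated chain carbon bound to an amine nitrogen, and it cannot be read: the limit of > 300 uM in this assay, at which 2 of the 4 values shown sit. Only one readable instance of this change therefore stands, and it shows neither that the change carries from one core to another nor that it fails to.

Open, going by these compounds, is whether a longer chain such as butyl, or a chain ending in an amine or a carboxylic acid, stays near compound 4 at 5.9 uM. Also open, on these data alone, is how chloro in place of bromo reads on the shared core.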